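Removing the amino group from a methoxy-bearing core

A few compounds are considered here, and "the series" means these few. Any claim that something is new, unique, unknown or untested is made for them only; others in the source may bear on it.

Compound 1 `C#Cc1cn([C@@H]2O[C@H](CO)[C@@H](O)[C@H]2O)c2ncnc(N(C)C)c12` gives 290 nM in a functional assay on HL-60 cells (Homo sapiens) for antiproliferative activity, read by XTT assay, with a stated time of 72 h; on this read-out lower numbers stand for stronger inhibition and higher numbers for weaker inhibition. Compound 2 `C#Cc1cn([C@@H]2O[C@H](CO)[C@@H](O)[C@H]2O)c2ncnc(NC)c12` gives 9060 nM. Compound 3 `C#Cc1cn([C@@H]2O[C@H](CO)[C@@H](O)[C@H]2O)c2nc(N)nc(OC)c12` gives only > 20000 nM, which is a limit of the assay and not a number.

Compound 3 therefore stands at the limit of > 20000 nM in this assay, at which 1 of the 3 values shown sits, with no exact value known. Compound 4 `C#Cc1cn([C@@H]2O[C@H](CO)[C@@H](O)[C@H]2O)c2ncnc(OC)c12` differs from it by one change: hydrogen in place of amino on an aromatic carbon. Going by the values given here, the single measured step, a 31-fold higher number from compound 1 to compound 2 (1.49 log units; beyond the scatter), concerns a different group at a different place, so it does not bear directly on this change. With compound 3 known only as a limit, no step size can be read from the data. Compound 4 is expected to remain weak, with an estimated 20000 nM (range 5000 nM to 60000 nM), which would mean a number no higher from compound 3 to compound 4 (the limit leaves the size open).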

Compound 4, half-maximal inhibitory concentration: 190 nM
Estimate against measurement, compound 4: 110-fold (2.02 log units) above; the measured number lies below the stated range.
By their numbers in this assay, from the lowest: compounds 4 and 1 (each within the scatter of the next); then compound 2. At a limit, above all of these: compound 3.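

Compound 3 stands at a limit of the assay and not at a number: the limit of > 20000 nM in this assay, at which 1 of the 4 values shown sits. On the aromatic carbon between two ring nitrogen atoms, hydrogen in place of amino gives an at least 100-fold lower number from compound 3 to compound 4 (2.02 log units; beyond the scatter) in this assay, so this one place has a large bearing on activity. With hydrogen there, methoxy in place of methylamino gives a 48-fold lower number from compound 2 to compound 4 (1.68 log units; beyond the scatter), whereas methoxy in place of dimethylamino gives a 1.5-fold lower number from compound 1 to compound 4 (0.18 log units; within the scatter), so methoxy and dimethylamino cannot be told apart here.

From the compounds shown here alone, it remains open whether amino on that carbon would cost as much alongside dimethylamino instead of methoxy. Also open, going by these compounds, is how an ethoxy group or a chlorine atom would fare in place of methoxy.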